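Aryl Swap on a Shared Core: Two Measured, One Expected

The compounds below may be only part of what the source reports. "The series", "measured", "known", "first", "only" and "open" are said of these compounds alone.

Two compounds have so far been tested in a functional assay on SW620/5-FU cells (Homo sapiens) for cytotoxicity, read by MTT assay, with a stated time of 48 h, in the presence of a further agent that is not named here; on this read-out lower numbers stand for an effect already at smaller amounts and higher numbers for an effect only at larger amounts of compound:

compound 1 `CCN(CC)c1cc(NC(=O)NNc2cc(-c3ccc(F)cc3)c3cnn(C)c3n2)cc(Cl)n1` gives 37000 nM
compound 2 `Cc1nn(C)c2nc(NNC(=O)Nc3cc(Cl)nc(Cl)c3)cc(-c3ccc(Cl)s3)c12` gives 29400 nM

Of the two numbers, compound 2 shows the smaller one, yet its gap to compound 1 lies within the scatter of this assay, so the two compounds count as alike rather than ranked.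

Compound 3 `COc1ccc(-c2cc(NNC(=O)Nc3cc(Cl)nc(Cl)c3)nc3c2c(C)nn3C)cc1` has not yet been measured. It differs from compound 2 in one place: 4-methoxyphenyl in place of 5-chlorothiophen-2-yl on an aromatic carbon. Going by the values given here, no step between two measured compounds is available that would show what such a swap does on this core; compounds 1 and 2 differ in several places at once and both land in the same region of this assay. The expected step is therefore a 1.0-fold higher number from compound 2 to compound 3 (0.01 log units; within the scatter), none beyond the scatter. Compound 3 is estimated at 30000 nM, with a range from 12000 nM to 75000 nM.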

Compound 3, half-maximal effective concentration: 9700 nM
Beside the measured number, compound 3's estimate is 3.1-fold (0.49 log units) above it; measured number outside the range, below it.
By their numbers in this assay, from the lowest: compound 3; then compounds 2 and 1 (each within the scatter of the next).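

In this assay the change from 5-chlorothiophen-2-yl to 4-methoxyphenyl gives a 3.0-fold lower number from compound 2 to compound 3 (0.48 log units; beyond the scatter) and so shows that the group on this aromatic carbon, opposite the ring nitrogen, can move the number, if only modestly. Compounds 1 and 2 differ in several places at once and could not show this for a single position. This rests on one pair, and nothing at hand explains why the number drops with this change.

As far as these compounds go, it remains open whether the lower number goes with the carbon-only six-membered ring or with its methoxy group, which a plain phenyl at this position would help to separate. From the compounds shown here alone, how an amine or a carboxylic acid on that ring would read also stays unknown.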